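Extending the Terminal Amine of Compound 2

The compounds below may be only part of what the source reports. "The series", "measured", "known", "first", "only" and "open" are said of these compounds alone.

This account concerns two measured ureas and one still unmeasured. Compound 1 `CN(C)CCNc1nc(-c2ccc(NC(=O)Nc3ccc(F)cc3)cc2)nc2c(Cl)c(Cl)sc12` carries a 4-fluorophenyl on an amide-type nitrogen; in a functional assay on MKN-45 cells (Homo sapiens) for cytotoxicity, read by MTT assay, with a stated time of 72 h (on this read-out lower numbers stand for stronger inhibition and higher numbers for weaker inhibition), compound 1 gives 1350 nM. Compound 2 `CN(C)CCNc1nc(-c2ccc(NC(=O)Nc3ccc(Cl)cc3Cl)cc2)nc2c(Cl)c(Cl)sc12` carries a 2,4-dichlorophenyl at that nitrogen instead; in this assay compound 2 gives 3460 nM. That single change is a 2.6-fold higher number from compound 1 to compound 2 (0.41 log units; beyond the scatter). On the numbers shown, compound 2 thus stands as the higher of the two, with compound 1 as its only neighbour.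

Compound 3 `CCN(CC)CCNc1nc(-c2ccc(NC(=O)Nc3ccc(Cl)cc3Cl)cc2)nc2c(Cl)c(Cl)sc12` differs from compound 2 at another place: diethylamino in place of dimethylamino on a saturated chain carbon, two bonds along the chain from a nitrogen on an aromatic ring. Going by the values given here, no measured step touches this part of the molecule; the one measured step, a 2.6-fold higher number from compound 1 to compound 2 (0.41 log units; beyond the scatter), concerns the aryl group on the amide-type nitrogen and therefore says nothing direct about the amine at the chain end. With nothing to point either way, the author expects no step beyond the scatter in this assay, roughly a 1.1-fold lower number from compound 2 to compound 3 (0.03 log units; within the scatter). Compound 3 is therefore estimated at 3200 nM, with a range from 1200 nM to 8500 nM.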

Compound 3, half-maximal inhibitory concentration: 1770 nM
Estimate against measurement, compound 3: 1.8-fold (0.26 log units) above; measured number inside the range.
By their numbers in this assay, from the lowest: compounds 1, 3 and 2 (each within the scatter of the next, the first and the last beyond it).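

Going by these compounds alone, this is the first measured step at the chain-end amine, and it shows that this position accepts diethylamino, with its 5 heavy atoms, in place of dimethylamino, with its 3, without a shift beyond the scatter (the exchange gives a 2.0-fold lower number from compound 2 to compound 3 (0.29 log units; within the scatter)). The earlier compounds spoke only to the aryl group on the amide-type nitrogen, and that change is the one of the two measured steps printed as beyond the scatter (a 2.6-fold higher number from compound 1 to compound 2 (0.41 log units; beyond the scatter)), so on the compounds shown the aryl group has moved the number in this assay and this amine exchange has not. No evidence is available to explain the size of this step, and the measured numbers alone do not supply a reason.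

Still open, as far as these compounds go, is whether a ring amine such as piperidine or morpholine at the chain end, a primary amine there, or a longer chain leading to the amine would move the number beyond the scatter in this assay and so mark a limit to what this position accepts. Also open is whether the exchange of dimethylamino for diethylamino would give a similar step alongside the 4-fluorophenyl group of compound 1, since the one step shown was read only with the 2,4-dichlorophenyl group in place.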